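The source may report more compounds than this note shows. Statements on the series, on what has been measured and on what is new or still open speak of the compounds shown alone.

Of the compounds shown here, three that share one core have been measured in a functional assay on MDA-MB-231 cells (Homo sapiens) for cytotoxicity, read by MTT assay, with a stated time of 72 h; a higher number here means that more compound is needed for the effect, a lower number that less compound is needed. Compound 1 `CCOC(=O)c1c(C)coc1-c1ccc2c(CC)cccc2c1OC` gives 3.9 ug/mL in this assay. Compound 2 `CCc1cccc2c(OC)c(-c3occ(C)c3C(=S)OC)ccc12` gives 5.8 ug/mL in this assay. Compound 3 `CCc1cccc2c(OC)c(-c3occ(C)c3COC)ccc12` gives 9.7 ug/mL in this assay, the highest of the three numbers, so it needs the most compound for the effect; its gap to compound 2 lies within the scatter, whereas its gap to compound 1 lies beyond it.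

Compound 4 `CCc1cccc2c(OC)c(-c3occ(C)c3CBr)ccc12` has not yet been measured. It differs from compound 3 by bromo in place of methoxy on a saturated chain carbon bound to an aromatic carbon. Going by the values given here, none of the measured steps touches that chain carbon itself, so they bear on this change only loosely. What they do show is that exchanging the group on the aromatic carbon of the same ring moves the number at most modestly, as in a 2.5-fold higher number from compound 1 to compound 3 (0.40 log units; beyond the scatter), and otherwise within the scatter, as in a 1.5-fold higher number from compound 1 to compound 2 (0.17 log units; within the scatter) and a 1.7-fold higher number from compound 2 to compound 3 (0.22 log units; within the scatter). Among the compounds with values here, with no closer precedent, the expectation is that compound 4 stays near compound 3. Compound 4 is thus expected to give a step of a 1.4-fold lower number from compound 3 to compound 4 (0.14 log units; within the scatter) in this assay, none beyond the scatter. Compound 4 is estimated at 7 ug/mL in this assay, with a range from 2.5 ug/mL to 20 ug/mL.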

Compound 4, concentration for half-maximal effect: 4.6 ug/mL
Compound 4: the middle estimate sits 1.5-fold (0.18 log units) above what was measured, within the range that was stated.
By their numbers in this assay, from the lowest: compounds 1, 4, 2 and 3 (each within the scatter of the next, the first and the last beyond it).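

Going by these compounds alone, this is the first change made on the saturated chain carbon bound to an aromatic carbon, and in this assay bromo in place of methoxy gives a 2.1-fold lower number from compound 3 to compound 4 (0.32 log units; beyond the scatter), so the group on this carbon can move the number by a modest step. The bromomethyl group is not set apart from the other two groups on the aromatic carbon, with a 1.3-fold lower number from compound 2 to compound 4 (0.10 log units; within the scatter) and a 1.2-fold higher number from compound 1 to compound 4 (0.07 log units; within the scatter); compound 3 now lies beyond the scatter from both compound 1 and compound 4 but within it from compound 2, so the four compounds do not split into two clear sets. Nothing shown here gives a measured reason for the step from methoxy to bromo.

As far as these compounds go, it remains open whether this step is specific to bromo or whether other groups on the same carbon, such as chloro, hydroxy, an amine or a longer ether chain, would give a similar number. From the compounds shown here alone, all four values also come from this assay alone, so how the step carries over to other cell types or to non-cancerous cells is unknown.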